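The source may hold more compounds than are shown below. What is called first, only, known or untested is meant among the compounds shown, and "the series" means these compounds.

Measured compounds in a functional assay on SNU-638 cells (Homo sapiens) for antiproliferative activity, read by sulforhodamine B assay, with a stated time of 72 h; a higher number here means a weaker inhibitor, a lower number a stronger inhibitor:
- compound 1, `CCOC(=O)c1cnc2ccc(-c3cnc(OC)c(NS(=O)(=O)c4ccc(F)cc4F)c3)cn12`: 360 nM
- compound 2, `COc1ncc(-c2ccc3ncc(C(=O)N4CCC(O)CC4)n3c2)cc1NS(=O)(=O)c1ccc(F)cc1F`: 270 nM

Compound 2 holds the lower of the two numbers in this assay, but the step of a 1.3-fold lower number from compound 1 to compound 2 (0.12 log units; within the scatter) is within the scatter, so the two compounds cannot be told apart on potency. Compound 3, `COc1ncc(-c2ccc3ncc(C(=O)NCc4ccncc4)n3c2)cc1NS(=O)(=O)c1ccc(F)cc1F`, is the next compound in line. Its change from compound 2 is ((pyridin-4-yl)methyl)amino in place of 4-hydroxypiperidin-1-yl on a carbonyl carbon. Within the data shown here, the only measured step that bears on this position, a 1.3-fold lower number from compound 1 to compound 2 (0.12 log units; within the scatter), swapped the ethoxy for the ring amide without a shift beyond the scatter, so this position has so far tolerated a change of group. Among the measured compounds shown here, the step from the ring amide to the open-chain amide in compound 3 is an exchange of comparable size, and the single measured step gives no ground to expect a shift beyond the scatter in either direction. Compound 3 is therefore expected to give about 300 nM in this assay, with a likely range from 120 nM to 750 nM, a step of a 1.1-fold higher number from compound 2 to compound 3 (0.05 log units; within the scatter) from compound 2.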

Compound 3, half-maximal inhibitory concentration: 490 nM
Compound 3: middle estimate off by 1.6-fold (0.21 log units), on the low side, and the stated range covers the measured number.
By their numbers in this assay, from the lowest: compounds 2, 1 and 3 (each within the scatter of the next).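

In this assay, ((pyridin-4-yl)methyl)amino in place of 4-hydroxypiperidin-1-yl gives a 1.8-fold higher number from compound 2 to compound 3 (0.26 log units; within the scatter), and the same group in place of ethoxy gives a 1.4-fold higher number from compound 1 to compound 3 (0.13 log units; within the scatter). Among these compounds, the carbonyl carbon has now carried ethoxy, a non-aromatic ring and an aromatic ring, and no step among the three compounds goes beyond the scatter, so this position has tolerated each of these exchanges. No measurement here explains why the numbers stay so close.

Still open, going by these compounds, is whether a different kind of group on the carbonyl carbon, such as a hydroxyl that would make a carboxylic acid or a plain amino group that would make a primary amide, would shift the number beyond the scatter. These three compounds also say nothing about changes elsewhere on the shared core.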